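The compounds below may be only part of what the source reports. "The series", "measured", "known", "first", "only" and "open" are said of these compounds alone.

In an ADME assay on Huh-7 cells (Homo sapiens) for cytotoxicity, with a stated time of 72 h (a lower number here means that less compound is tolerated, a higher number that more compound is tolerated), the three measured compounds give limits, not numbers. Compound 1 `CCCS(=O)(=O)Nc1ccc2c(c1)S(=O)(=O)N=C(c1c(O)c(-c3cccs3)nn(CCC(C)C)c1=O)N2` gives > 1000 nM, which is a limit. Compound 2 `CC(C)CCn1nc(-c2cccs2)c(O)c(C2=NS(=O)(=O)c3cc(N(C)S(C)(=O)=O)ccc3N2)c1=O` gives > 33000 nM, also a limit. Compound 3 `COCN(c1ccc2c(c1)S(=O)(=O)N=C(c1c(O)c(-c3cccs3)nn(CCC(C)C)c1=O)N2)S(C)(=O)=O` gives > 1000 nM, again a limit, so its place is only bounded on one side. Compound 4 `CC(C)CCn1nc(-c2cccs2)c(O)c(C2=NS(=O)(=O)c3cc(CS(C)(=O)=O)ccc3N2)c1=O` carries (methylsulfonyl)methyl in place of (methoxymethyl)(methylsulfonyl)amino on an aromatic carbon. The measured changes at this same place are a step that the two limits leave unreadable from compound 1 to compound 2, a step that the two limits leave unreadable from compound 1 to compound 3 and a step that the two limits leave unreadable from compound 2 to compound 3. Among the measured compounds shown here, none of them has a readable size, so no step of known size or direction can be carried over to this assay. The estimated change is a step that the limit leaves unreadable from compound 3 to compound 4. Compound 4 is expected at about 20000 nM, within an estimated range of 3000 nM to 100000 nM.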

Compound 4, half-maximal cytotoxic concentration: > 33000 nM
Compound 4: only a limit was reported; the forecaster's own chance of this, stated with the estimate: 85%; middle value at least 1.6-fold (0.21 log units) away from the limit.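

Among the compounds shown here, compound 4, like compound 1, compound 2 and compound 3, gives only a limit, so no step to compound 4 can be read. Going by these compounds, what stays open is the concentration at which any of them becomes cytotoxic in this assay.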